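Hydrazone aryl swap on the methoxyphenyl series

A few compounds are considered here, and "the series" means these few. Any claim that something is new, unique, unknown or untested is made for them only; others in the source may bear on it.

Compound 1 `CSc1nn(-c2ccccc2)c2ncnc(N/N=C/c3ccc(Br)cc3)c12` gives 10.9 nM in a functional assay on MCF7 cells (Homo sapiens) for inhibition, read by sulforhodamine B assay, with a stated time of 48 h; a higher number here means a weaker inhibitor, a lower number a stronger inhibitor. Compound 2 `CSc1nn(-c2ccccc2)c2ncnc(N/N=C/c3ccc(O)cc3)c12` gives 10.3 nM in this assay, and compound 3 `COc1ccc(-n2nc(SC)c3c(N/N=C/c4ccc(Br)cc4)ncnc32)cc1` gives 23 nM. Compound 3 thus carries the highest number of the three measured: the step of a 2.1-fold higher number from compound 1 to compound 3 (0.32 log units; beyond the scatter) lies beyond the scatter, and the gap between compound 3 and compound 2 also exceeds the scatter, so compound 3 is the weakest inhibitor measured so far.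

Compound 4 `COc1ccc(-n2nc(SC)c3c(N/N=C/c4cccc(O)c4)ncnc32)cc1` has not been measured. It differs from compound 3 in one place: 3-hydroxyphenyl in place of 4-bromophenyl on a carbon with a double bond to nitrogen. Going by the values given here, the only measured step that bears on this change is a 1.1-fold lower number from compound 1 to compound 2 (0.02 log units; within the scatter), where hydroxy replaced bromo on the same kind of aryl and the number hardly moved. The precedent is partial, since compound 4 carries 3-hydroxyphenyl whereas compound 2 does not carry that group. On this basis no step beyond the scatter is expected in this assay, in either direction. The estimate for compound 4 is 20 nM, with a range of 8 nM to 50 nM, which corresponds to an expected step of a 1.2-fold lower number from compound 3 to compound 4 (0.06 log units; within the scatter).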

Compound 4, half-maximal inhibitory concentration: 9.9 nM
For compound 4 the middle estimate is 2.0-fold (0.31 log units) above the measured one, and the stated range covers the measured number.
By their numbers in this assay, from the lowest: compounds 4, 2 and 1 (each within the scatter of the next); then compound 3.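

In this assay the aryl on the carbon with a double bond to nitrogen proves able to move the number: 3-hydroxyphenyl in place of 4-bromophenyl gives a 2.3-fold lower number from compound 3 to compound 4 (0.37 log units; beyond the scatter) and so a modest step that clears the scatter. The earlier exchange of hydroxy for bromo, a 1.1-fold lower number from compound 1 to compound 2 (0.02 log units; within the scatter) on the core of compound 1, had left this aryl looking silent, so that reading does not carry over to every exchange of this kind at this position. No measurement on hand bears on why the two steps differ.

Still open is whether the step from compound 3 to compound 4 belongs to the hydroxy group itself, to where it sits on the ring, or to the 4-methoxyphenyl-bearing core it stands on, as the compounds shown hold no pair that separates these readings. Also open, from the compounds shown here alone, is how other groups on this aryl would read on the same core, such as an amine, a carboxylic acid or a longer alkoxy chain, and whether any of them would go beyond the scatter in either direction.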